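This account rests on a few compounds, and the source may have more. Where it says the series, first, only, none or still open, it means among the compounds named here.

Working notes on the series. The shared core carries a variable aryl group; compound 1 `COC(=O)c1sc2cc(-c3ccsc3)cnc2c1N` bears thiophen-3-yl there, compound 2 `COC(=O)c1sc2cc(-c3ccc4c(ccn4C)c3)cnc2c1N` a methylindolyl group. In a functional assay on A-375 cells (Homo sapiens) for inhibition, read by sulforhodamine B assay, with a stated time of 48 h (on this read-out lower numbers stand for stronger inhibition of growth and higher numbers for weaker inhibition of growth), compound 1 gives 12100 nM. Compound 2 gives 21200 nM in this assay, and the gap between compound 1 and compound 2 lies within the usual scatter, so the two numbers are read as one level with no order between them. Compound 3 `COC(=O)c1sc2cc(-c3ccccc3N)cnc2c1N` is not yet measured in this assay. It differs from compound 1 by 2-aminophenyl in place of thiophen-3-yl on an aromatic carbon. For the measured compounds named here, no step between measured compounds touches this position, so the expectation rests on compound 1 alone, whose 12100 nM sets the anchor, and the step from compound 1 to compound 3 is expected to be small, a 1.2-fold lower number from compound 1 to compound 3 (0.08 log units; within the scatter), in no firm direction and not clearly beyond the scatter. Compound 3 is therefore estimated at 10000 nM, with a range from 3500 nM to 30000 nM.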

Compound 3, concentration for 50% growth inhibition: 2500 nM
Estimate against measurement, compound 3: 4.0-fold (0.60 log units) above, and the stated range ends above it.
By their numbers in this assay, from the lowest: compound 3; then compounds 1 and 2 (each within the scatter of the next).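

The aryl position on the shared core is not silent in this assay: 2-aminophenyl in place of thiophen-3-yl gives a 4.8-fold lower number from compound 1 to compound 3 (0.68 log units; beyond the scatter). Compound 1 and compound 2 had stood at one level, so the earlier aryl groups gave no sign that this position could separate values beyond the scatter. The change swaps the five-membered sulfur-containing ring for a six-membered aromatic ring of carbon only and adds an amino group in the same step, so this one comparison cannot assign the shift to either feature, and no measured data bear on why it occurs.

The compounds shown leave open whether plain phenyl, without the amino group, would give a number nearer compound 3 or compound 1. They also leave open whether a hydroxyl group or a methylamino group could stand in place of the amino group on the phenyl ring.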